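The compounds below may be only part of what the source reports. "The series", "measured", "known", "first", "only" and "open" are said of these compounds alone.

Compound 1 `CC(O)(CSc1ccc(F)cc1)C(=O)Nc1cccc(S(F)(F)(F)(F)F)c1`: 21900 nM
Compound 2 `CC(O)(CSc1ccc(C(F)(F)F)cc1)C(=O)Nc1cccc(S(F)(F)(F)(F)F)c1`: 27300 nM
Compound 3 `CC(O)(CSc1ccccc1C(F)(F)F)C(=O)Nc1cccc(S(F)(F)(F)(F)F)c1`: 21000 nM

All three values come from a functional assay on VCaP cells (Homo sapiens) for antiproliferative activity, read by propidium iodide staining, with a stated time of 96 h; a higher number here means a weaker inhibitor, a lower number a stronger inhibitor. Compound 1 cannot be ranked against the other two, since its steps to both lie within the scatter. Compound 4 `CC(O)(COc1ccc(C#N)cc1)C(=O)Nc1cccc(S(F)(F)(F)(F)F)c1`, not yet measured, carries 4-cyanophenoxy in place of (4-fluorophenyl)sulfanyl on a saturated chain carbon, two bonds along the chain from a carbonyl carbon and an oxygen on a saturated carbon. The measured changes to the aromatic group were all small: a 1.2-fold higher number from compound 1 to compound 2 (0.10 log units; within the scatter), a 1.0-fold lower number from compound 1 to compound 3 (0.02 log units; within the scatter) and a 1.3-fold lower number from compound 2 to compound 3 (0.11 log units; within the scatter). As far as these compounds go, none of them replaces the sulfur with an oxygen, so that part of the change is untested and the estimate stays wide. No step beyond the scatter is expected in this assay, and the expected step is a 1.0-fold higher number from compound 1 to compound 4 (0.00 log units; within the scatter). Compound 4 is expected at 22000 nM, with an estimated range of 9000 nM to 50000 nM.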

Compound 4, half-maximal inhibitory concentration: 26600 nM
Beside the measured number, compound 4's estimate is 1.2-fold (0.08 log units) below it, within the range that was stated.
By their numbers in this assay, from the lowest: compounds 3, 1, 4 and 2 (each within the scatter of the next).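

In this assay, 4-cyanophenoxy in place of (4-fluorophenyl)sulfanyl gives a 1.2-fold higher number from compound 1 to compound 4 (0.08 log units; within the scatter). The earlier steps shown here changed only the aromatic group, whereas this one also swaps sulfur for oxygen, and the number at this saturated chain carbon still stays within the scatter. No measured evidence accounts for this result. As far as these compounds go, because the oxygen and the nitrile arrived together, the effect of each alone remains unknown. Also open, from the compounds shown here alone, is how an amine in place of that oxygen, or a longer chain at this carbon, would read.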